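Opening a Morpholine: From Compound 1 to Compound 3

The source may hold more compounds than are shown below. What is called first, only, known or untested is meant among the compounds shown, and "the series" means these compounds.

Measured compounds:
compound 1, `NC(=O)Nc1sc(-c2ccccc2)cc1C(=O)NCC1CNCCO1`: "not determined" (no result reported)
compound 2, `NC(=O)Nc1sc(-c2ccc(C(=O)N3CCOCC3)cc2)cc1C(=O)N[C@H]1CCCNC1`: 610 nM

Compound 1 has no single number in a functional assay on HT-29 cells (Homo sapiens); a higher number here means that more compound is needed for the effect, a lower number that less compound is needed; its result was not determined. For the measured compounds named here, the only measured reference is compound 2, which in this assay gives 610 nM. Going by the values given here, no step has been computed between compound 1 and compound 2, so their relationship can only be read from that one value.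

Compound 3, `CNCCNC(=O)c1cc(-c2ccccc2)sc1NC(N)=O`, is the next compound in line. It differs from compound 1 in one place: (methylamino)methyl in place of morpholin-2-yl on a saturated chain carbon bound to an amide-type nitrogen. The group that leaves carries one six-membered non-aromatic ring with two hetero atoms; the group that enters has no ring.

Among the compounds with values here, since compound 1 carries no number, no step can be stated. A modest loss in this assay is expected, possibly no more than the scatter, anchored on what compound 2 shows at 610 nM. Compound 3 is therefore expected to give about 1200 nM in this assay, with a range from 250 nM to 6000 nM.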

Compound 3, half-maximal effective concentration: 580 nM
Beside the measured number, compound 3's estimate is 2.1-fold (0.32 log units) above it; measured number inside the range.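

No step can be read from compound 1 to compound 3, as compound 1 has no single number in this assay to set against the new result. No further data bearing on this result are available.

The compounds shown leave open how exchanging morpholin-2-yl for (methylamino)methyl changes the response in this assay on this core.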